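From Chloro to Fluoro on a Shared Core

This account rests on a few compounds, and the source may have more. Where it says the series, first, only, none or still open, it means among the compounds named here.

Three close relatives have numbers in a functional assay on the whole organism for positive allosteric modulation, with Mus musculus as the target; on this read-out higher numbers stand for an effect only at larger amounts of compound and lower numbers for an effect already at smaller amounts. Compound 1 (`CCC(=O)N(c1ccc(Cl)cc1)C1CCCC1N(C)C`) gives 3 mg/kg, and two further entries for it carry no single number. Compound 2 (`CCC(=O)N(c1ccc(OC)cc1)C1CCCC1N(C)C`) gives 30 mg/kg; 30 mg/kg (2 entries), and compound 3 (`CCC(=O)N(c1ccc(C)cc1)C1CCCC1N(C)C`) gives 30 mg/kg; 30 mg/kg (2 entries). The value of compound 1 thus lies under both of theirs on this scale.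

Compound 4 (`CCC(=O)N(c1ccc(F)cc1)C1CCCC1N(C)C`) keeps the core of compound 1 and changes one group: fluoro in place of chloro on an aromatic carbon. The change sits on an aromatic carbon of a six-membered aromatic ring of carbon only, para to a large group. Going by the values given here, no measured pair differs in one place only, so nothing shows directly how large such a step is in this assay. A modest move toward larger doses is expected, and it may stay within the scatter. That expectation rests on compound 1 at 3 mg/kg and on compound 3 at 30 mg/kg; 30 mg/kg (2 entries). The estimated change is a 2.7-fold higher number from compound 1 to compound 4 (0.43 log units; beyond the scatter). Compound 4 is expected at 8 mg/kg, with an estimated range of 2 mg/kg to 30 mg/kg.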

Compound 4, dose for half-maximal effect: 5 mg/kg
Compound 4: middle estimate off by 1.6-fold (0.20 log units), on the high side; the range from low to high includes it.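

In this assay, going by these compounds alone, fluoro in place of chloro on the aromatic carbon gives the first step that can be read directly, and it comes to a 1.7-fold higher number from compound 1 to compound 4 (0.22 log units; within the scatter) on the shared core. At this place, para to a large group, the read-out therefore does not separate fluoro from chloro, so the two groups can be exchanged here without a change that stands out from the scatter. Nothing given here bears on what lies behind this result.

As far as these compounds go, it remains open whether bromo, trifluoromethyl or a nitrile at this same place would also stay within the scatter of compound 1, and what a plain hydrogen there would give. The compounds shown also leave open how a longer acyl chain or a different amine elsewhere on the core would read.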